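Compound 3: cyano in place of bromo

The source may hold more compounds than are shown below. What is called first, only, known or untested is meant among the compounds shown, and "the series" means these compounds.

In an ADME assay on L02 cells (Homo sapiens) for cytotoxicity, read by MTT assay, with a stated time of 24 h (a higher number here means a weaker inhibitor, a lower number a stronger inhibitor), compound 1 `O=C1/C(=C/c2ccncc2)CN(S(=O)(=O)c2ccc(F)cc2)C/C1=C\c1ccccc1F` gives 15600 nM and compound 2 `O=C1/C(=C/c2ccncc2)CN(S(=O)(=O)c2ccc(Br)cc2)C/C1=C\c1ccccc1F` gives 19400 nM. Among the measured compounds shown here, compound 2 therefore cannot be separated from compound 1, the only other measured compound, as the two values lie within the scatter.

Compound 3 `N#Cc1ccc(S(=O)(=O)N2C/C(=C\c3ccncc3)C(=O)/C(=C/c3ccccc3F)C2)cc1` carries cyano in place of bromo on an aromatic carbon, para to a large group, turning 4-bromophenyl into 4-cyanophenyl: cyano in place of bromo on an aromatic carbon.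

For the measured compounds named here, one measured step bears on this change, at the same aromatic carbon: a 1.2-fold higher number from compound 1 to compound 2 (0.09 log units; within the scatter), for bromo in place of fluoro. Going by the values given here, no cyano compound has been measured, so this evidence is indirect. On that basis, no step beyond the scatter is expected in this assay. The estimated step is a 1.1-fold lower number from compound 2 to compound 3 (0.06 log units; within the scatter). For compound 3 the estimated value is 17000 nM, with an expected range of 8000 nM to 35000 nM.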

Compound 3, half-maximal inhibitory concentration: > 20000 nM
Compound 3 was reported as a limit; the forecaster's own chance of this, stated with the estimate: 5%; middle value at least 1.1-fold (0.07 log units) from the limit.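

In this assay the reading for compound 3 is a limit and not a number, so the 4-cyanophenyl compound gives only a floor: the limit of > 20000 nM in this assay, at which 1 of the 3 values shown sits. The two steps are floors as well, an at least 1.0-fold higher number from compound 2 to compound 3 (0.01 log units; that floor lies within the scatter) and an at least 1.2-fold higher number from compound 1 to compound 3 (0.10 log units; that floor lies within the scatter), so cyano is not separated from either halogen. Among the compounds shown here, still, the halogen pair could not show that a non-halogen group on this aromatic carbon, para to a large group, one adding a hydrogen-bond acceptor, brings no step towards a stronger inhibitor.

Going by these compounds, how far the true value of compound 3 lies past the limit stays open, and with it whether cyano differs from bromo or fluoro at all. Also open, on these data alone, is whether an amine or a carboxylic acid at this position would move the reading in either direction.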